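A few compounds are considered here, and "the series" means these few. Any claim that something is new, unique, unknown or untested is made for them only; others in the source may bear on it.

In a functional assay on HCT-116 cells (Homo sapiens) for antiproliferative activity, read by MTT assay, with a stated time of 48 h (a lower number here means a stronger inhibitor, a higher number a weaker inhibitor), compound 1 `COc1ccc(-c2c(Nc3ccc(F)cc3)c3ccc(OC)cc3oc2=O)cc1` stands at "not determined" (no result reported) and offers no comparison. Among the measured compounds shown here, compound 2 `COc1ccc(Nc2c(C(=O)C(F)(F)F)c(=O)oc3cc(OC)ccc23)cc1` gives 61200 nM as the only number so far, so it has no rank among measured compounds yet. Compound 3 `COc1ccc2c(Nc3ccc(F)cc3)c(C(=O)C(F)(F)F)c(=O)oc2c1` differs from compound 2 in one place, with fluoro in place of methoxy on an aromatic carbon. For the measured compounds named here, no measured pair shows the size of such a change, so no step beyond the usual scatter is expected in this assay here. The estimated move a 1.2-fold lower number from compound 2 to compound 3 (0.09 log units; within the scatter) is therefore small. Compound 3 is expected at 50000 nM with 20000 nM to 110000 nM as its estimated range.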

Compound 3, half-maximal inhibitory concentration: 11700 nM
Compound 3: the middle estimate sits 4.3-fold (0.63 log units) above what was measured; the whole stated range lies above it.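

In this assay, replacing (4-methoxyphenyl)amino with (4-fluorophenyl)amino gives a 5.2-fold lower number from compound 2 to compound 3 (0.72 log units; beyond the scatter) and this shows that the group at this position can shift the read-out beyond the usual scatter. Compound 3, at 11700 nM, is the lower of the two measured values. Nothing measured here offers a reason for this step.

A single pair cannot separate the effect of adding fluoro from that of removing methoxy. On these data alone, how chloro, an amine or a carboxylic acid at this position would compare remains open.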